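Swapping the Chlorophenyl Arm for a Methylpiperazine

The source may report more compounds than this note shows. Statements on the series, on what has been measured and on what is new or still open speak of the compounds shown alone.

Compound 1 `CC(C)(C)n1cc2c(n1)C(=O)CC1(CCN(C(=O)c3cc(-c4ccc(Cl)cc4)nc4ccccc34)CC1)O2` was tested in a functional assay on MDA-MB-231 cells (Homo sapiens) for inhibition, read by MTT assay, with a stated time of 72 h; on this read-out higher numbers stand for weaker inhibition and lower numbers for stronger inhibition. In this assay compound 1 gives only a limit, > 10000 nM, so its standing among the compounds shown is a limit rather than a number. Compound 2 `COc1ccc(-c2cc(C(=O)N3CCC4(CC3)CC(=O)c3nn(C(C)(C)C)cc3O4)c3ccccc3n2)cc1` likewise gives a limit in this assay, > 10000 nM. Compound 3 `CN(C)c1ccc(-c2cc(C(=O)N3CCC4(CC3)CC(=O)c3nn(C(C)(C)C)cc3O4)c3ccccc3n2)cc1` also gives a limit in this assay, > 10000 nM. The measured steps, a step that the two limits leave unreadable from compound 1 to compound 2, a step that the two limits leave unreadable from compound 1 to compound 3 and a step that the two limits leave unreadable from compound 2 to compound 3, cannot be read because every value sits at the limit of > 10000 nM in this assay, at which 3 of the 3 values shown sit.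

Compound 4 `CN1CCN(c2cc(C(=O)N3CCC4(CC3)CC(=O)c3nn(C(C)(C)C)cc3O4)c3ccccc3n2)CC1` differs from compound 1 as follows: 4-methylpiperazin-1-yl in place of 4-chlorophenyl on an aromatic carbon. Going by the values given here, none of the measured steps bears readably on this change. Compound 4 is therefore expected to remain at the limit, with an estimated step that the limit leaves unreadable from compound 1 to compound 4. The estimate for compound 4 is 15000 nM, with an expected range from 4000 nM to 60000 nM.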

Compound 4, half-maximal inhibitory concentration: 8130 nM
Beside the measured number, compound 4's estimate is 1.8-fold (0.27 log units) above it, and the stated range covers the measured number.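

Going by these compounds alone, at this position, next to the ring nitrogen, compound 4 with its 4-methylpiperazin-1-yl is the first compound in this assay to give a number rather than a limit. Replacing each aryl arm gives an at least 1.2-fold lower number from compound 1 to compound 4 (0.08 log units; that floor lies within the scatter), an at least 1.2-fold lower number from compound 2 to compound 4 (0.08 log units; that floor lies within the scatter) and an at least 1.2-fold lower number from compound 3 to compound 4 (0.08 log units; that floor lies within the scatter). These are only floors, and the true sizes of the steps stay unknown because the other compounds give no number: the limit of > 10000 nM in this assay, at which 3 of the 4 values shown sit.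

As far as these compounds go, it remains open whether a morpholine, or a piperazine without the methyl, would also give a number here. The compounds shown also cannot tell whether the non-aromatic ring or its methyl counts.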